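A few compounds are considered here, and "the series" means these few. Any claim that something is new, unique, unknown or untested is made for them only; others in the source may bear on it.

In a functional assay on DU-145 cells (Homo sapiens) for antiproliferative activity, read by sulforhodamine B assay, with a stated time of 48 h (a lower number here means a stronger inhibitor, a higher number a weaker inhibitor), compound 1 `CCCCN(C)C(=O)CCCCOc1cc(OC)c(OC)c2oc(-c3ccc(OC)cc3)c(O)c(=O)c12` gives 10800 nM. Compound 2 `COc1ccc(-c2oc3c(OC)c(OC)cc(OCCCCC(=O)N4CCN(C)CC4)c3c(=O)c2O)cc1` carries 4-methylpiperazin-1-yl in place of butyl(methyl)amino on a carbonyl carbon, and the result is an at least 3.7-fold higher number from compound 1 to compound 2 (0.56 log units; beyond the scatter). Compound 2 reads > 40000 nM, which is a limit of the assay and not a number. For the measured compounds named here, it is the only such reading so far: the limit of > 40000 nM in this assay, at which 1 of the 2 values shown sits.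

Compound 3 `COc1ccc(-c2oc3c(OC)c(OC)cc(OCCCCCC(=O)N4CCN(C)CC4)c3c(=O)c2O)cc1` differs from compound 2 in the chain: ((4-methylpiperazin-1-yl)carbonyl)methyl in place of (4-methylpiperazin-1-yl)carbonyl on a saturated chain carbon, four bonds along the chain from an oxygen on an aromatic ring. In words, this places ((4-methylpiperazin-1-yl)carbonyl)methyl in place of (4-methylpiperazin-1-yl)carbonyl on a saturated chain carbon, four bonds along the chain from an oxygen on an aromatic ring.

Going by the values given here, no measured step changes the chain, so the evidence is indirect. Compound 3 keeps the 4-methylpiperazin-1-yl group whose arrival in compound 2 came with an at least 3.7-fold higher number from compound 1 to compound 2 (0.56 log units; beyond the scatter), and so it is expected to remain a weak inhibitor. No step beyond the scatter is expected, and the reading may again be only a limit. The estimated change is a number no higher from compound 2 to compound 3 (the limit leaves the size open). For compound 3 the expected value is 40000 nM, with an estimated range from 15000 nM to 80000 nM.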

Compound 3, half-maximal inhibitory concentration: 13200 nM
Beside the measured number, compound 3's estimate is 3.0-fold (0.48 log units) above it, and the stated range ends above it.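

Replacing (4-methylpiperazin-1-yl)carbonyl with ((4-methylpiperazin-1-yl)carbonyl)methyl on a saturated chain carbon, four bonds along the chain from an oxygen on an aromatic ring, gives an at least 3.0-fold lower number from compound 2 to compound 3 (0.48 log units; beyond the scatter) in this assay, so this position responds to the change even with the 4-methylpiperazin-1-yl group kept in place. The reading for compound 2 is a limit of the assay and not a number, so this step has no fixed size: the limit of > 40000 nM in this assay, at which 1 of the 3 values shown sits. With ((4-methylpiperazin-1-yl)carbonyl)methyl in place of butyl(methyl)carbamoyl, the comparison gives a 1.2-fold higher number from compound 1 to compound 3 (0.09 log units; within the scatter), so the weak reading of compound 2 cannot be tied to the 4-methylpiperazin-1-yl group alone, as the step to it from compound 1 could have suggested.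

The compounds shown leave open whether 2-((4-methylpiperazin-1-yl)carbonyl)ethyl or 3-((4-methylpiperazin-1-yl)carbonyl)propyl would continue this trend, and whether the butyl(methyl)amino amide would respond in the same way to a longer chain. They also leave open how a morpholine amide or a free carboxylic acid at the end of the chain would read in this assay.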